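Methoxy in place of dimethylamino on the nitro ring

The compounds below may be only part of what the source reports. "The series", "measured", "known", "first", "only" and "open" are said of these compounds alone.

Compound 1 `Cc1ccc(C)c(S(=O)(=O)N(C)/N=C/c2cnn3ccc(C#N)cc23)c1`: in an assay on isolated protein for inhibition of phosphatidylinositol 4,5-bisphosphate 3-kinase catalytic subunit beta isoform (Homo sapiens), read by 33P incorporation, with a stated time of 60 min (a higher number here means a weaker inhibitor, a lower number a stronger inhibitor), compound 1 gives > 1000 nM
Compound 2 `CN(C)c1ccc([N+](=O)[O-])cc1S(=O)(=O)N(C)/N=C/c1cnn2ccc(C#N)cc12`: in this assay compound 2 gives 44 nM

Within the data shown here, only two compounds have been measured, and they differ in more than one place, so no single step between measured compounds is available. Compound 1 sits at a limit of the assay, and its value is not a number but (the limit of > 1000 nM in this assay, at which 1 of the 2 values shown sits). Compound 2 is the only compound with a measured number; it stands alone, with nothing else shown to compare it against.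

Compound 3 `COc1ccc([N+](=O)[O-])cc1S(=O)(=O)N(C)/N=C/c1cnn2ccc(C#N)cc12` is not yet measured. It differs from compound 2 by methoxy in place of dimethylamino on an aromatic carbon, in words methoxy in place of dimethylamino on an aromatic carbon. Among the measured compounds shown here, with no comparable step among the measured compounds, the size of the change can only be guessed. The step of a 1.6-fold higher number from compound 2 to compound 3 (0.20 log units; within the scatter) is expected to be small, a slight loss that may not exceed the usual scatter. Compound 3 is therefore estimated at 70 nM, with a range from 20 nM to 250 nM.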

Compound 3, half-maximal inhibitory concentration in the phosphatidylinositol 4,5-bisphosphate 3-kinase catalytic subunit beta isoform assay: 63 nM
Compound 3: the middle estimate sits 1.1-fold (0.05 log units) above what was measured; measured number inside the range.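

In the phosphatidylinositol 4,5-bisphosphate 3-kinase catalytic subunit beta isoform assay, methoxy in place of dimethylamino on this aromatic carbon, ortho to a large group and para to a nitro group, gives a 1.4-fold higher number from compound 2 to compound 3 (0.16 log units; within the scatter), so the two groups cannot be told apart on this read-out. At this position, then, inhibition does not depend on dimethylamino in particular, and a group with fewer heavy atoms serves equally well within this pair. The same change does register in a physicochemical assay for solubility (on this read-out higher numbers stand for higher solubility and lower numbers for lower solubility), where compound 2 gives 0.5 ug/mL and compound 3 gives 0.2 ug/mL, so compound 3 is the less soluble of the two: the measured solubility of compound 2, 0.5 ug/mL, and of compound 3, 0.2 ug/mL, a 2.5-fold lower number (0.40 log units; beyond the scatter).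

On these data alone, it remains open whether this tolerance extends beyond these two groups, for instance to an ethoxy group, a primary amine or a carboxylic acid, and whether any of them would recover solubility while holding the inhibition. In the phosphatidylinositol 4,5-bisphosphate 3-kinase catalytic subunit beta isoform assay compound 1 gives > 1000 nM, which is a limit of the assay, and because it differs from compound 2 in more than one place, the contribution of the nitro group cannot be read from it: the limit of > 1000 nM in the phosphatidylinositol 4,5-bisphosphate 3-kinase catalytic subunit beta isoform assay, at which 1 of the 3 values shown sits.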